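From Fluoro to Butylcarbamoyl: Estimating Growth Inhibition

The compounds below may be only part of what the source reports. "The series", "measured", "known", "first", "only" and "open" are said of these compounds alone.

Compound 1 `CC[C@@H]1C(=O)N(C)c2cnc(-n3ccc4cc(C(N)=O)ccc43)nc2N1C1CCCC1` gives 1850 nM
Compound 2 `CCC1C(=O)N(C)c2cnc(-n3ccc4cc(C(=O)NC)ccc43)nc2N1c1ccn(C)n1` gives 13300 nM
Compound 3 `CCC1C(=O)N(C)c2cnc(-n3ccc4cc(F)ccc43)nc2N1c1ccn(C)n1` gives 6070 nM

In a functional assay on K562 cells (Homo sapiens) for antiproliferative activity, read by CCK-8 assay, with a stated time of 72 h (a higher number here means a weaker inhibitor of growth, a lower number a stronger inhibitor of growth), compound 3 has the second highest of the three numbers, below compound 2 and above compound 1. Compound 4 `CCCCNC(=O)c1ccc2c(ccn2-c2ncc3c(n2)N(c2ccn(C)n2)C(CC)C(=O)N3C)c1` differs from it by one change: butylcarbamoyl in place of fluoro on an aromatic carbon. For the measured compounds named here, the one measured step that bears on this is a 2.2-fold lower number from compound 2 to compound 3 (0.34 log units; beyond the scatter) (fluoro in place of methylcarbamoyl). Reversed, that modest step points to a higher number when a carbamoyl group replaces fluoro. Compound 2 carries methylcarbamoyl rather than butylcarbamoyl, so the effect of the longer name's butyl part is unmeasured. The expected step is a 2.0-fold higher number from compound 3 to compound 4 (0.30 log units; within the scatter) (an estimate). For compound 4 the estimated value is 12000 nM (expected range 4500 nM to 30000 nM).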

Compound 4, concentration for 50% growth inhibition: 14100 nM
For compound 4 the middle estimate is 1.2-fold (0.07 log units) below the measured one; low and high end bracket the measured number.
By their numbers in this assay, from the lowest: compound 1; then compound 3; then compounds 2 and 4 (each within the scatter of the next).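

In this assay, butylcarbamoyl in place of fluoro on this aromatic carbon gives a 2.3-fold higher number from compound 3 to compound 4 (0.37 log units; beyond the scatter), so a carbamoyl group with a longer chain also sits on the weaker side of fluoro. Methylcarbamoyl and butylcarbamoyl read alike, with a 1.1-fold higher number from compound 2 to compound 4 (0.03 log units; within the scatter), so at this position the added propyl shows no effect beyond the scatter. Nothing at hand explains these numbers. Still open, from the compounds shown here alone, is how an amine or a carboxylic acid would read on this aromatic carbon, and whether a chain longer than butyl on the amide nitrogen would keep the same level.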